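This account rests on a few compounds, and the source may have more. Where it says the series, first, only, none or still open, it means among the compounds named here.

Going by the values given here, compound 2 `COc1cc2ncnc(Nc3ccc(Br)cc3F)c2cc1OCCCN1CCNCCNCCNCC1` gives 15200 nM in a functional assay on A549 cells (Homo sapiens) for antiproliferative activity, read by MTT assay, with a stated time of 72 h (a lower number here means a stronger inhibitor, a higher number a weaker inhibitor), one of only two numbers recorded, and compound 1 `COc1cc2ncnc(Nc3cccc(Br)c3)c2cc1OCCCN1CCNCCNCCNCC1`, which gives 14700 nM, stands so close that the step of a 1.0-fold higher number from compound 1 to compound 2 (0.01 log units; within the scatter) is within the scatter. Compound 3 `COc1cc2ncnc(Nc3ccc(C#N)cc3F)c2cc1OCCCN1CCNCCNCCNCC1` differs from compound 2 by cyano in place of bromo on an aromatic carbon. Among the compounds with values here, no measured step swaps bromo for cyano; the only step available, a 1.0-fold higher number from compound 1 to compound 2 (0.01 log units; within the scatter), changed the bromophenyl pattern without moving this assay beyond the scatter, so little movement is expected here either. Compound 3 is therefore expected to give about 20000 nM, within 8000 nM to 50000 nM. The expected shift is a 1.3-fold higher number from compound 2 to compound 3 (0.12 log units; within the scatter).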

Compound 3, half-maximal inhibitory concentration: > 50000 nM
Compound 3: only a limit was reported (the forecaster's own chance of this, stated with the estimate: 10%); at least 2.5-fold (0.39 log units) between middle value and limit.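

In this assay, the earlier change of bromophenyl pattern stayed within the scatter, but this carbon proves sensitive to what sits on it: cyano in place of bromo alone gives an at least 3.2-fold higher number from compound 2 to compound 3 (0.51 log units; beyond the scatter). The wider change to 4-cyano-2-fluorophenyl gives a similar result, an at least 3.4-fold higher number from compound 1 to compound 3 (0.53 log units; beyond the scatter). The value of compound 3 is a limit, not a number: the limit of > 50000 nM in this assay, at which 1 of the 3 values shown sits.

The compounds shown leave open how far the number truly rises, and whether chloro, methyl or methoxy on this carbon would behave like bromo or like cyano.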